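This account rests on a few compounds, and the source may have more. Where it says the series, first, only, none or still open, it means among the compounds named here.

Compounds measured so far:
compound 1 `COc1ccc(-c2ccc3c(c2)C(=O)C(=O)N3Cc2ccc(F)cc2)cc1` with 560 nM
compound 2 `COc1ccc(CN2C(=O)C(=O)c3cc(-c4ccc(F)cc4)ccc32)cc1` with 240 nM

In a functional assay on K562 cells (Homo sapiens) for antiproliferative activity, read by MTT assay, with a stated time of 48 h (on this read-out lower numbers stand for stronger inhibition and higher numbers for weaker inhibition), compound 2 gives the lower of the two numbers; compound 1 gives a higher number in this assay, and the gap between them lies beyond the usual scatter. Compound 3 `COc1ccc(CN2C(=O)C(=O)c3cc(-c4ccncc4)ccc32)cc1` has not been measured. It differs from compound 2 in one place: pyridin-4-yl in place of 4-fluorophenyl on an aromatic carbon. Among the compounds with values here, no measured pair shows this change, so its effect is unknown. A small step is expected from compound 2 to compound 3, toward a slightly higher number, roughly at the edge of the scatter: a 1.7-fold higher number from compound 2 to compound 3 (0.22 log units; within the scatter). Compound 3 is therefore estimated at 400 nM, between 120 nM and 1500 nM.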

Compound 3, half-maximal inhibitory concentration: 40 nM
The estimate for compound 3 lay 10-fold (1.00 log units) above the measured number; the whole stated range lies above it.
By their numbers in this assay, from the lowest: compound 3; then compound 2; then compound 1.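

In this assay, this aromatic carbon proves sensitive to the ring it carries: pyridin-4-yl in place of 4-fluorophenyl gives a 6.0-fold lower number from compound 2 to compound 3 (0.78 log units; beyond the scatter) and so takes the series well past the earlier gap. The change adds a ring nitrogen, counted as a hydrogen-bond acceptor, and removes the fluorine, and this single pair cannot separate those two parts. No measurement here accounts for the step. Going by these compounds, whether an amine or a carboxylic acid on the same carbon would do as well remains open. So does whether pyridin-4-yl would act alike on compound 1.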